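A few compounds are considered here, and "the series" means these few. Any claim that something is new, unique, unknown or untested is made for them only; others in the source may bear on it.

Measured so far:
- Compound 1, `NC(=O)c1c(NC(=O)c2ccc(C(F)(F)F)cc2)sc2c1CCN(Cc1ccc(Cl)cc1Cl)C2`: 14900 nM
- Compound 2, `Cc1ccc(C(=O)Nc2sc3c(c2C(N)=O)CCN(Cc2ccc(Cl)cc2Cl)C3)cc1`: 19900 nM
- Compound 3, `NC(=O)c1c(NC(=O)c2ccccc2Cl)sc2c1CCN(C(=S)Nc1ccccc1C(F)(F)F)C2`: 10600 nM

All three were tested in a functional assay on HL-60 cells (Homo sapiens) for antiproliferative activity, with a stated time of 24 h; on this read-out higher numbers stand for weaker inhibition and lower numbers for stronger inhibition. Compound 1 gives 14900 nM, compound 2 gives 19900 nM and compound 3 gives 10600 nM. The move from compound 1 to compound 2 is the change (methyl in place of trifluoromethyl on an aromatic carbon), and it made a step of a 1.3-fold higher number from compound 1 to compound 2 (0.13 log units; within the scatter). Compound 3 sits on a core that differs from the core of compound 1 by more than one change; the difference between the two cores is not broken down here. Its value and those of compound 1 and compound 2 all lie within the usual scatter of one another, so no order among them can be read.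

Compound 4, `Cc1ccccc1NC(=S)N1CCc2c(sc(NC(=O)c3ccccc3Cl)c2C(N)=O)C1`, has not yet been measured in this assay. It arises from compound 3 by the change (methyl in place of trifluoromethyl on an aromatic carbon). For the measured compounds named here, this is the same kind of change as the one from compound 1 to compound 2, but not the same: there the methyl sat para to a large group, here it sits ortho to a large group, and the two cores differ as well.

Because the earlier step of a 1.3-fold higher number from compound 1 to compound 2 (0.13 log units; within the scatter) stayed within the scatter, the expectation for compound 4 is a step of about a 1.2-fold higher number from compound 3 to compound 4 (0.09 log units; within the scatter) from compound 3 in this assay, that is, little change. Compound 4 is estimated at 13000 nM, with a likely span from 5000 nM to 32000 nM.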

Compound 4, half-maximal inhibitory concentration: 22600 nM
Beside the measured number, compound 4's estimate is 1.7-fold (0.24 log units) below it; the range from low to high includes it.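

In this assay, putting methyl in place of trifluoromethyl on the aromatic ring gave a 2.1-fold higher number from compound 3 to compound 4 (0.33 log units; beyond the scatter), a modest step. Set beside the earlier step on the other core, the size of this step cannot be told apart from it, so the data give no sign that the core alters what this change does: the same change on two cores in this assay, a 1.3-fold higher number (0.13 log units; within the scatter) from compound 1 to compound 2 and a 2.1-fold higher number (0.33 log units; beyond the scatter) from compound 3 to compound 4, 1.6-fold (0.20 log units) apart, within the scatter of two such steps. For the compounds shown here, this shows only that two pairs are compatible with the change carrying over from one core to the other; it does not show that the step has the same size on both, and it does not explain why one step stayed within the scatter while the other went beyond it.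

The compounds shown leave open how a hydrogen, a chlorine or a methoxy group would read in the place of methyl and trifluoromethyl on either core, and whether an amine or a carboxylic acid there would move the number further than methyl does. They also leave open whether the same change would give a similar step on a third core, or in any read-out other than this assay.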